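The source may report more compounds than this note shows. Statements on the series, on what has been measured and on what is new or still open speak of the compounds shown alone.

Compound 1 `COc1ccc(-c2nc(C(=O)/C=C\Nc3ccc4[nH]ccc4c3)c3ccccn23)cc1` gives 28700 nM in a functional assay on MDA-MB-231 cells (Homo sapiens) for cytotoxicity, read by MTT assay, with a stated time of 48 h; a higher number here means a weaker inhibitor, a lower number a stronger inhibitor. Compound 2 `O=C(/C=C\Nc1ccc2cc[nH]c2c1)c1nc(-c2ccc(C(F)(F)F)cc2)n2ccccc12` gives > 30000 nM in this assay; that figure is a limit of the assay, not a number. Compound 2 therefore stands at the weak end of the two values shown, at the limit of > 30000 nM in this assay, at which 1 of the 2 values shown sits. Compound 3 `O=C(/C=C\Nc1ccc2[nH]ccc2c1)c1nc(-c2ccc(C(F)(F)F)cc2)n2ccccc12` is not yet measured; it differs from compound 2 by 1H-indol-5-yl in place of 1H-indol-6-yl on an amine nitrogen. Within the data shown here, no measured step of this kind exists here, so nothing beyond the scatter is expected a number no higher from compound 2 to compound 3 (the limit leaves the size open). For compound 3 the estimate is 30000 nM, in a range from 15000 nM to 60000 nM, with a limit as a likely outcome.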

Compound 3, half-maximal inhibitory concentration: 1180 nM
Compound 3: middle estimate off by 25-fold (1.41 log units), on the high side; the whole stated range lies above it.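

In this assay, with trifluoromethyl kept on the aromatic carbon, the attachment of the indole to the amine nitrogen proves decisive: 1H-indol-5-yl in place of 1H-indol-6-yl gives an at least 25-fold lower number from compound 2 to compound 3 (1.40 log units; beyond the scatter). With 1H-indol-5-yl kept, the group on the aromatic carbon also matters, as trifluoromethyl in place of methoxy gives a 24-fold lower number from compound 1 to compound 3 (1.39 log units; beyond the scatter). The value of compound 2 is a limit of the assay, not a number, which leaves the true size of the first step open: the limit of > 30000 nM in this assay, at which 1 of the 3 values shown sits.

From the compounds shown here alone, it remains open whether a nitrile or a chlorine in place of trifluoromethyl would keep this lower number, and whether 1H-indol-4-yl on the amine nitrogen would read like 1H-indol-5-yl. The compounds shown also do not tell why either change acts as it does.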